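Swapping Nitro for Amino on a Shared Benzimidazole-Type Core

The compounds below may be only part of what the source reports. "The series", "measured", "known", "first", "only" and "open" are said of these compounds alone.

Three compounds share the same kind of core and were tested in an ADME assay on MT4 cells (Homo sapiens) for cytotoxicity, read by MTT assay, with a stated time of 96 h; on this read-out lower numbers stand for higher toxicity in this test and higher numbers for lower toxicity in this test. Compound 1 `CCN(CC)CC(=O)Nc1ccc(-c2nc3cc(C(F)(F)F)ccc3n2C)cc1` gives 9000 nM. Compound 2 `O=[N+]([O-])c1ccc(-c2nc3cc(Cl)c(Cl)cc3[nH]2)cc1` gives 17000 nM. Compound 3 `Oc1ccc(-c2nc3cc(C(F)(F)F)ccc3[nH]2)cc1` gives 17000 nM. Compound 2 and compound 3 match at the digits shown, and compound 1 lies within the usual scatter of both, so across these three measured compounds no difference can be called real.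

The next compound, compound 4 `Nc1ccc(-c2nc3cc(Cl)c(Cl)cc3[nH]2)cc1`, has not yet been measured in this assay. It differs from compound 2 in one place: amino in place of nitro on an aromatic carbon. Among the compounds with values here, nothing among the measured compounds shows what such a change does here, since no pair of measured compounds differs in exactly this way, and the three values that are known all sit inside the scatter of one another.

Within the data shown here, with no measured step to lean on, the expected shift is no change at the digits printed from compound 2 to compound 4 (within the scatter), which amounts to no change beyond the scatter. On that basis compound 4 is estimated to give 17000 nM in this assay, with a range from 7000 nM to 40000 nM.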

Compound 4, half-maximal cytotoxic concentration: 17000 nM
For compound 4 middle estimate and measured number coincide at the digits printed; the range from low to high includes it.
By their numbers in this assay, from the lowest: compounds 1, 2, 3 and 4 (each within the scatter of the next).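

In this assay, within the data shown here, amino in place of nitro on an aromatic carbon, para to a large group, gives no change at the digits printed from compound 2 to compound 4 (within the scatter), and this is the first measured change in one place on the shared core. At this position, then, the read-out does not separate the two groups, even though the swap changes the heavy atoms and the hydrogen-bond donors and acceptors counted there, so this single pair gives no sign that the choice between nitro and amino matters for cytotoxicity in these cells. No measured information here explains this outcome.

Going by these compounds, it remains open whether other groups at the same position, such as a carboxylic acid, a nitrile or a longer chain ending in an amine, would also stay within the scatter of compound 2. The same swap on a core carrying trifluoromethyl in place of the two chlorines, as in compound 3, also remains an open question, since one pair cannot show whether the outcome holds beyond the core of compound 2.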